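Trifluoromethyl for Methyl: A Step Without a Precedent

The source may report more compounds than this note shows. Statements on the series, on what has been measured and on what is new or still open speak of the compounds shown alone.

Measured so far, in an assay on isolated protein for inhibition of serine/threonine-protein kinase PLK1 (Homo sapiens), read by radiometric assay and 33P incorporation, with a stated time of 40 min, tested at 20 uM, in the presence of a further agent that is not named here; on this read-out higher numbers stand for more inhibition at the one concentration tested (going by the name of the read-out) and lower numbers for less inhibition:
compound 1, `CCNc1cc(-c2ccc(NC(=O)Nc3ccc(OC)cc3)cc2C)ccn1`, gives 45.8%
compound 2, `CCNc1cc(-c2ccc(NC(=O)Nc3c(C)cccc3C)cc2C)ccn1`, gives 42.1%

Compound 2 has the lower of the two numbers in this assay, but its nearest neighbour is compound 1, and the gap is within the usual scatter, so the two cannot be told apart. Among the compounds with values here, the one measured step, a number 3.7 percentage points lower from compound 1 to compound 2 (within the scatter), changed the group on an amide-type nitrogen and also stayed within the scatter.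

Compound 3, `CCNc1cc(-c2ccc(NC(=O)Nc3c(C)cccc3C)cc2C(F)(F)F)ccn1`, is not yet measured. Its change from compound 2 is trifluoromethyl in place of methyl on an aromatic carbon. Within the data shown here, no measured step touches this part of the shared core, so the single step that exists, the one from compound 1 to compound 2, bears on it only in showing that one change elsewhere left this assay unmoved. On that thin basis, the step from compound 2 to compound 3 is expected to stay within the scatter, that is a number 0.1 percentage points lower from compound 2 to compound 3 (within the scatter), with no clear direction. Compound 3 is therefore estimated at 42%, somewhere between 20% and 65%.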

Compound 3, a percentage reported as inhibition, at one concentration (the size of the read-out at that concentration, not a potency): 59.2%
Estimate against measurement, compound 3: 17.2 percentage points below, within the range that was stated.
By their numbers in this assay, from the lowest: compounds 2 and 1 (each within the scatter of the next); then compound 3.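

In this assay, within the data shown here, this aromatic carbon, ortho to a 2-(ethylamino)pyridin-4-yl group, is the first place where a single change gives a step beyond the scatter: a number 17.1 percentage points higher from compound 2 to compound 3 (beyond the scatter). The change is modest in size, but it shows that the read-out can respond to an edit on this part of the shared core, which the earlier change on the amide-type nitrogen did not show. Trifluoromethyl and methyl have the same counts of rings, hydrogen-bond donors, hydrogen-bond acceptors and net charge, and no measurement available here accounts for the higher number.

The compounds shown leave open whether the gain is specific to trifluoromethyl or would also appear with a chlorine atom, a nitrile or an ethyl chain on the same carbon. They also leave open whether the same exchange would raise the number with the 4-methoxyphenyl group of compound 1 in place of the 2,6-dimethylphenyl group, and how the compounds would compare in potency, as each number here is a reading at one concentration.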